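Pentyl on selenium in the amino-selanyl core: compound 2 to 4

The source may report more compounds than this note shows. Statements on the series, on what has been measured and on what is new or still open speak of the compounds shown alone.

Going by the values given here, in a functional assay on HTB-54 cells (Homo sapiens) for cytotoxicity, read by MTT assay, with a stated time of 72 h (on this read-out lower numbers stand for stronger inhibition of growth and higher numbers for weaker inhibition of growth), compound 2 `Nc1nc([SeH])nc2ncccc12` gives 96600 nM, the highest of the three numbers measured so far. Compound 1 `CCCCC[Se]c1nc([Se]CCCCC)c2cccnc2n1` gives 60500 nM in this assay, which stands within the scatter of compound 2. Among the compounds with values here, compound 3 `[SeH]c1nc([SeH])c2cccnc2n1` gives 7930 nM; the step of a 12-fold lower number from compound 2 to compound 3 (1.09 log units; beyond the scatter) is the only single-site step measured, and it concerns a different position from the change at hand.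

Compound 4 `CCCCC[Se]c1nc(N)c2cccnc2n1` differs from compound 2 by pentyl in place of hydrogen on a selenium. Within the data shown here, no measured pair differs by this change alone. Compound 1 and compound 3 differ at two places, both of them a pentyl against a hydrogen on selenium; in this assay compound 1 gives 60500 nM and compound 3 gives 7930 nM, so the pentyl-bearing member of that pair shows the higher number. On that basis the step of a 1.2-fold higher number from compound 2 to compound 4 (0.09 log units; within the scatter) is expected to be modest, toward a higher number if anything, and possibly not beyond the scatter. Compound 4 is therefore expected at about 120000 nM, within a range from 45000 nM to 320000 nM, with a fair chance that this assay reports only a limit.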

Compound 4, concentration for total growth inhibition: 51000 nM
The estimate for compound 4 lay 2.4-fold (0.37 log units) above the measured number, within the range that was stated.
By their numbers in this assay, from the lowest: compound 3; then compounds 4, 1 and 2 (each within the scatter of the next).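

In this assay, pentyl in place of hydrogen on a selenium can now be read as a single change: the step of a 1.9-fold lower number from compound 2 to compound 4 (0.28 log units; within the scatter) shows no difference that can be told from the scatter. The same holds for one nitrogen atom in place of the group of 6 heavy atoms on an aromatic carbon, with the step of a 1.2-fold lower number from compound 1 to compound 4 (0.07 log units; within the scatter) also giving no resolved difference. Among the single-site steps, only the step of a 12-fold lower number from compound 2 to compound 3 (1.09 log units; beyond the scatter) lies beyond the scatter, and neither new change approaches it.

Still open, on these data alone, is whether methyl, a longer chain such as octyl, or benzyl on the selenium would give a step beyond the scatter. No supporting evidence bears on these results.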